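Swapping a Hydroxyphenyl for Pyridinyl on a Shared Core

This account rests on a few compounds, and the source may have more. Where it says the series, first, only, none or still open, it means among the compounds named here.

Three compounds built on one shared core have been examined in a toxicity assay on CHO cells (Cricetulus griseus) for cytotoxicity, read by MTT assay, with a stated time of 72 h; on this read-out higher numbers stand for weaker inhibition and lower numbers for stronger inhibition. Compound 1 `O=C1/C(=C/c2cccc([N+](=O)[O-])c2)S/C(=N\c2ccccc2)N1Cc1ccco1` was entered in this assay but compound 1 gave "not determined" (no result reported). Compound 2 `O=C1/C(=C/c2ccc([N+](=O)[O-])cc2)S/C(=N\c2ccccc2)N1Cc1ccco1` likewise has no reading, since in this assay compound 2 gave "not determined" (no result reported). Compound 3 `O=C1/C(=C/c2ccc(O)cc2)S/C(=N\c2ccccc2)N1Cc1ccco1` is the only one of the three with any reported outcome. For compound 3 this assay reported a limit rather than a number, namely > 250000 nM. Compound 3 therefore stands at the only marked point among the three, sitting at the limit of > 250000 nM in this assay, at which 1 of the 3 values shown sits, while the other two entries carry no figure at all.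

Compound 4 `O=C1/C(=C/c2ccccn2)S/C(=N\c2ccccc2)N1Cc1ccco1` has not yet been measured. It differs from compound 3 in a single place: pyridin-2-yl in place of 4-hydroxyphenyl on a double-bonded chain carbon bound to a double-bonded ring carbon. Among the measured compounds shown here, no step between two measured compounds exists in this set, so the size of this change cannot be read from a neighbouring pair. Because compound 3 rests at the limit of > 250000 nM in this assay, at which 1 of the 3 values shown sits, the step is expected to be small, essentially none beyond the usual scatter, with an estimated shift of a number no higher from compound 3 to compound 4 (the limit leaves the size open). Compound 4 is accordingly expected to give about 250000 nM in this assay, with a plausible range from 100000 nM to 600000 nM, and it may again be reported only as a limit.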

Compound 4, half-maximal inhibitory concentration: > 250000 nM
Compound 4 was reported as a limit; the forecaster's own chance of this, stated with the estimate: 70%; the middle value sits exactly at the limit.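

Compound 3 and compound 4 both end at a limit rather than a number in this assay, so the swap of 4-hydroxyphenyl for pyridin-2-yl gives no readable step. Both share one limit: the limit of > 250000 nM in this assay, at which 2 of the 4 values shown sit.

The compounds shown leave open how strongly, if at all, either compound inhibits these cells, and whether the swap changes that.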